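The source may report more compounds than this note shows. Statements on the series, on what has been measured and on what is new or still open speak of the compounds shown alone.

Series notes. Compound 3 `Cc1oc(=O)oc1COC(=O)N[C@@H](CCC(=O)C=[N+]=[N-])C(=O)OC(C)C` and compound 1 `CCOC(=O)[C@H](CCC(=O)C=[N+]=[N-])NC(=O)OCc1oc(=O)oc1C` share one core; compound 2 `CC(C)C[C@H](N)C(=O)N[C@@H](CCC(=O)C=[N+]=[N-])C(=O)OC(C)C` and compound 4 `CCOC(=O)[C@H](CCC(=O)C=[N+]=[N-])NC(=O)[C@@H](N)CC(C)C` share another. In an ADME assay on a cell-free system (plasma, Mus musculus) for metabolic stability, read by LC-MS, with a stated time of 60 min, tested at 10 uM (a lower number here means that less of the compound is left, a higher number that more of the compound is left), compound 3 gives 0%, and compound 1 gives 0%. The step of no change at the digits printed from compound 3 to compound 1 (within the scatter) corresponds to hydrogen in place of methyl on a saturated chain carbon bound to an oxygen next to a carbonyl group and a saturated chain carbon. Compound 2 gives 0% in this assay, level with compounds 1 and 3 within the scatter. How the core of compound 2 differs from the core of compound 3 is not broken down here. Compound 4 carries the same change against compound 2 that compound 1 carries against compound 3, namely (hydrogen in place of methyl on a saturated chain carbon bound to an oxygen next to a carbonyl group and a saturated chain carbon); the two places read alike word for word, so the surroundings of the change are the same. The step from compound 2 to compound 4 is expected to be no change at the digits printed from compound 2 to compound 4 (within the scatter). This rests on the earlier step of no change at the digits printed from compound 3 to compound 1 (within the scatter), and on compound 2 already standing at 0%. Compound 4 is estimated at 0% in this assay, with an expected range from 0% to 8%.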

Compound 4, percent of the compound remaining: 0%
Compound 4: middle estimate and measured number agree at the digits printed; the range from low to high includes it.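

In this assay, replacing isopropoxycarbonyl with ethoxycarbonyl gives no change at the digits printed from compound 2 to compound 4 (within the scatter), and the same change on the other core reads alike: the same change on two cores in this assay, no change at the digits printed (within the scatter) from compound 3 to compound 1 and no change at the digits printed (within the scatter) from compound 2 to compound 4, 0 percentage points apart, within the scatter of two such steps Across these two pairs, the change therefore carries from one core to the other without any difference in this read-out. This does not show that the change is without consequence, as all four compounds stand at the same value, the bottom of the read-out, so any difference that would appear only at a shorter time or on a core leaving more compound behind cannot be seen here.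

On these data alone, a carboxylic acid, an amide or a longer chain in place of ethoxycarbonyl remains open on both cores, as does whether any such group would leave a measurable amount of compound in this assay. Also open, as far as these compounds go, is how the change would read with an amine or a ring-bearing group in place of the groups that set the core of compound 2 apart from the core of compound 3.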